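The source may report more compounds than this note shows. Statements on the series, on what has been measured and on what is new or still open speak of the compounds shown alone.

Compound 1 `C#CCn1cc(C(=O)NC(CC(=O)NC2CCCCC2)c2ccccc2)c(=O)c2cc(F)c(Cl)nc21` gives 2300 nM in a functional assay on PA-1 cells (Homo sapiens) for cytotoxicity, read by MTT assay, with a stated time of 72 h; on this read-out lower numbers stand for stronger inhibition and higher numbers for weaker inhibition. Compound 2 `C#CCn1cc(C(=O)NC(CC(=O)Nc2ccccc2)c2ccccc2)c(=O)c2ccc(Cl)nc21` gives 540 nM in this assay. Compound 3 `C#CCn1cc(C(=O)NC(CC(=O)Nc2ccccc2)c2ccccc2)c(=O)c2cccnc21` gives > 10000 nM in this assay, which is a limit of the assay and not a number. That value sits at the limit of > 10000 nM in this assay, at which 1 of the 3 values shown sits.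

Among the two numbers obtained, compound 1 gives the higher one and compound 2 the lower, so compound 1 is the weaker of the two in this assay.

Compound 4 `C#CCn1cc(C(=O)NC(CC(=O)NC2CCCC2)c2ccccc2)c(=O)c2cc(F)c(Cl)nc21` differs from compound 1 in one place: cyclopentyl in place of cyclohexyl on an amide-type nitrogen. Within the data shown here, the only measured step, an at least 18-fold higher number from compound 2 to compound 3 (1.26 log units; beyond the scatter), concerns a different part of the shared core and says nothing about the ring on the amide-type nitrogen. Among the measured compounds shown here, no measured step therefore bears on the change from compound 1 to compound 4, and a step of no more than the usual scatter is expected in this assay, in no particular direction, which is what a 1.1-fold higher number from compound 1 to compound 4 (0.04 log units; within the scatter) expresses. Compound 4 is estimated at 2500 nM, with a range from 1000 nM to 6500 nM.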

Compound 4, half-maximal inhibitory concentration: 680 nM
For compound 4 the middle estimate is 3.7-fold (0.57 log units) above the measured one, and the stated range ends above it.
By their numbers in this assay, from the lowest: compounds 2 and 4 (each within the scatter of the next); then compound 1. At a limit, above all of these: compound 3.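

Up to this point, the only measured step lay on the shared core, so nothing showed whether the ring on the amide-type nitrogen matters in this assay. The change from cyclohexyl to cyclopentyl gives a 3.4-fold lower number from compound 1 to compound 4 (0.53 log units; beyond the scatter), which shows that this position does respond and that even a swap from a six-membered to a five-membered carbon ring can move the number beyond the scatter. Nothing measured here explains why the five-membered ring gives the lower number.

Going by these compounds, it remains open whether a still smaller ring such as cyclobutyl would lower the number further, or whether an open chain such as isobutyl would do as well as either ring. The compounds shown also leave open whether the same ring change would have a similar effect on a core without the fluoro group.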